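Permeability of a Benzyl Ring Swap on Two Cores

The compounds below may be only part of what the source reports. "The series", "measured", "known", "first", "only" and "open" are said of these compounds alone.

Measured compounds:
compound 1 `COc1cccc(CNCCCNc2ccnc3cc(Cc4ccc(F)cc4)ccc23)c1O`: 23 10^-6 cm/s
compound 2 `COc1ccc(F)cc1CNCCCNc1ccnc2cc(Cc3ccc(F)cc3)ccc12`: 23 10^-6 cm/s
compound 3 `COc1cccc(CNCCCNc2ccnc3cc(-c4cc(C(F)(F)F)cc(C(F)(F)F)c4)ccc23)c1O`: 237 10^-6 cm/s

In an ADME assay for permeability, using PAMPA, with a stated time of 30 min, at pH 7.4 (on this read-out lower numbers stand for lower permeability and higher numbers for higher permeability), compound 1 gives 23 10^-6 cm/s, and compound 2 gives 23 10^-6 cm/s. The two share a core and differ only by 5-fluoro-2-methoxyphenyl in place of 2-hydroxy-3-methoxyphenyl on a saturated chain carbon bound to an amine nitrogen; this change produced no change at the digits printed from compound 1 to compound 2 (within the scatter), so the two values sit together within the scatter of the method.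

Compound 3 carries a different core and gives 237 10^-6 cm/s in this assay, the highest of the three numbers and beyond the scatter against both compound 1 and compound 2. The difference between the core of compound 3 and the core of compound 1 is not broken down here.

Compound 4 `COc1ccc(F)cc1CNCCCNc1ccnc2cc(-c3cc(C(F)(F)F)cc(C(F)(F)F)c3)ccc12` has not yet been measured in this assay. It stands to compound 3 as compound 2 stands to compound 1: the change is 5-fluoro-2-methoxyphenyl in place of 2-hydroxy-3-methoxyphenyl on a saturated chain carbon bound to an amine nitrogen, at the same place in the same words, so it is the same change seen once already. Because no change at the digits printed from compound 1 to compound 2 (within the scatter) lay within the scatter on the first core, the expectation is that the step on the second core is also small, that is no change at the digits printed from compound 3 to compound 4 (within the scatter). On that basis compound 4 is estimated to give 237 10^-6 cm/s in this assay, with the expected range running from 120 10^-6 cm/s to 450 10^-6 cm/s.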

Compound 4, apparent permeability: 237 10^-6 cm/s
Compound 4: the middle estimate sits on the measured number at the digits printed; the range from low to high includes it.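

On the core of compound 3, putting 5-fluoro-2-methoxyphenyl in place of 2-hydroxy-3-methoxyphenyl on a saturated chain carbon bound to an amine nitrogen gives, in this assay, no change at the digits printed from compound 3 to compound 4 (within the scatter). Set beside the same change on the core of compound 1, the step carries from one core to the other without a difference that stands out from the scatter: the same change on two cores in this assay, no change at the digits printed (within the scatter) from compound 1 to compound 2 and no change at the digits printed (within the scatter) from compound 3 to compound 4, 1.0-fold (0.00 log units) apart, within the scatter of two such steps This shows that the change left the read-out of this assay unmoved on both of these cores, but it rests on only two pairs and one assay, it does not show that the same would hold on any further core or in any other read-out, and since neither step moved the number, it does not test whether a change with a real effect would carry over in the same way.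

The swap alters the ring in more than one way at once, and the compounds shown do not separate the loss of the hydroxy group from the arrival of the fluorine. Also open, from the compounds shown here alone, is whether a nitrile or a carboxylic acid on that ring, or a longer chain between the two amine nitrogens, would leave the read-out as unmoved on both cores.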